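The compounds below may be only part of what the source reports. "The series", "measured", "known", "first", "only" and "open" are said of these compounds alone.

Going by the values given here, compound 2 `Clc1ccc(-c2csc(N/N=C/c3ccc(N4CCCC4)cc3)n2)cc1` is the only compound with a number in an assay on isolated protein for inhibition of Amine oxidase [flavin-containing] B (Homo sapiens), read by fluorescence and Amplex Red, with a stated time of 30 min; a lower number here means a stronger inhibitor, a higher number a weaker inhibitor: compound 2 gives 761000 nM. Compound 1 `Cc1ccc(-c2csc(N/N=C/c3ccc(N4CCCC4)cc3)n2)cc1` gives > 100000 nM in this assay, which is a limit of the assay and not a number. The step from compound 1 to compound 2 a step that the limit leaves unreadable from compound 1 to compound 2 cannot be read because of the limit of > 100000 nM in this assay, at which 1 of the 2 values shown sits. Compound 3 `Fc1ccc(-c2csc(N/N=C/c3ccc(N4CCCC4)cc3)n2)cc1` differs from compound 2 by fluoro in place of chloro on an aromatic carbon. Among the compounds with values here, no measured step has numbers at both ends, so no direction beyond the scatter is expected. Compound 3 is therefore expected near 800000 nM, between 200000 nM and 3000000 nM, a step of a 1.1-fold higher number from compound 2 to compound 3 (0.02 log units; within the scatter).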

Compound 3, half-maximal inhibitory concentration: 426000 nM
Compound 3: middle estimate off by 1.9-fold (0.27 log units), on the high side; the measured number falls inside the stated range.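

Going by these compounds alone, the change from 4-chlorophenyl to 4-fluorophenyl gives a 1.8-fold lower number from compound 2 to compound 3 (0.25 log units; within the scatter) in this assay and is the first step here with numbers at both ends. At this place on the aromatic ring, the two halogens therefore cannot be told apart. Compound 1 holds a limit and not a number, so the steps from it to the other two compounds cannot be read: the limit of > 100000 nM in this assay, at which 1 of the 3 values shown sits.

Still open, as far as these compounds go, is whether an amine or a carboxylic acid at this place would give a step beyond the scatter.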